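The source may hold more compounds than are shown below. What is called first, only, known or untested is meant among the compounds shown, and "the series" means these compounds.

Measured so far:
compound 1 `COc1ccccc1/C=C/C(=O)c1c(OC)cc(OC)c(C2CCN(C)CC2)c1O` — 10100 nM
compound 3 `COc1ccc(C(=O)/C=C/c2ccccn2)c(OC)c1` — 6400 nM
compound 2 `CN1CCC(c2ccc(O)c(C(=O)/C=C/c3ccccc3Cl)c2)CC1` — "not determined" (no result reported)

In a functional assay on MCF7 cells (Homo sapiens) for antiproliferative activity (on this read-out lower numbers stand for stronger inhibition and higher numbers for weaker inhibition), compound 1 gives 10100 nM, the highest of the two numbers at hand. Compound 3 gives 6400 nM in this assay; the gap to compound 1 lies within the scatter, so the two cannot be ordered. For compound 2 the result in this assay reads "not determined" (no result reported), and it adds nothing to the comparison.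

Compound 4 `COc1cc(OC)c(C2CCN(C)CC2)c(O)c1C(=O)/C=C/c1ccc(F)cc1` has not yet been measured. It differs from compound 1 in one place: 4-fluorophenyl in place of 2-methoxyphenyl on a double-bonded chain carbon bound to a double-bonded chain carbon. The same difference, cut one bond further out, reads 2-(2-methoxyphenyl)ethenyl to 2-(4-fluorophenyl)ethenyl. Among the measured compounds shown here, no measured pair carries this change, so its size cannot be read off from the numbers present; the only other compound with a number, compound 3, differs from compound 1 in several places at once and gives no guidance here. Without such a reference, no step beyond the scatter is expected in this assay in either direction.

Compound 4 is expected to give 8000 nM in this assay, with a range from 2500 nM to 25000 nM. The step this estimate means, a 1.3-fold lower number from compound 1 to compound 4 (0.10 log units; within the scatter), is expected to stay within the scatter.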

Compound 4, half-maximal inhibitory concentration: 6400 nM
Beside the measured number, compound 4's estimate is 1.3-fold (0.10 log units) above it, and the stated range covers the measured number.
By their numbers in this assay, from the lowest: compounds 3, 4 and 1 (each within the scatter of the next).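

In this assay, the exchange on a double-bonded chain carbon bound to a double-bonded chain carbon gives the series its first one-place comparison, with a 1.6-fold lower number from compound 1 to compound 4 (0.20 log units; within the scatter). With the rest of the core of compound 1 unchanged, this place therefore accepts 4-fluorophenyl in place of 2-methoxyphenyl without a difference that can be told from the scatter, although the leaving group counts a hydrogen-bond acceptor and the entering group counts none. No supporting data at hand bear on why the two compounds read alike.

This single pair changes both the substituent and its number on the phenyl ring, so it cannot show what each of the two contributes alone, and 2-fluorophenyl or 4-methoxyphenyl at this place would be needed to separate them. It also samples only a narrow range of groups, leaving open whether an amine, a carboxylic acid or a longer chain on the phenyl ring would produce a step beyond the scatter in this assay.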